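The source may report more compounds than this note shows. Statements on the series, on what has been measured and on what is new or still open speak of the compounds shown alone.

The three measured compounds share a core carrying an aryl amide or urea, and all were tested in an ADME assay on HS27 cells (Homo sapiens) for antiproliferative activity, read by MTT assay, with a stated time of 24 h; a higher number here means a weaker inhibitor, a lower number a stronger inhibitor. Compound 1 `O=C(Nc1ccc(-n2ccc3c(NC(=O)c4ccccc4)ncnc32)cc1)c1ccc(Cl)c(Cl)c1` gives 5000 nM. Compound 2 `O=C(Nc1ccc(-n2ccc3c(NC(=O)c4ccccc4)ncnc32)cc1)c1ccc(Cl)c(C(F)(F)F)c1`, in which the change is a 1.1-fold higher number from compound 1 to compound 2 (0.04 log units; within the scatter), gives 5500 nM. Compound 3 `Nc1ncnc2c1ccn2-c1ccc(NC(=O)Nc2ccc(Cl)c(Cl)c2)cc1` gives 2900 nM, the lowest of the three numbers, but its gaps to compound 1 and to compound 2 are both within the scatter, so no order among the three can be read from these numbers.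

Compound 4 `O=C(Nc1ccc(-n2ccc3c(NC(=O)c4ccccc4)ncnc32)cc1)Nc1ccc(Cl)c(Cl)c1` differs from compound 3 by benzoyl in place of hydrogen on a nitrogen on an aromatic ring. Within the data shown here, no measured step makes exactly this change; the only measured step, from compound 1 to compound 2, concerns a different position and was within the scatter. Compound 1 and compound 2 both carry the benzamido group, and their numbers stand close to that of compound 3, which suggests the step to compound 4 in this assay will be small. Compound 4 is therefore expected to show a step of a 1.4-fold higher number from compound 3 to compound 4 (0.14 log units; within the scatter), giving an estimated value of 4000 nM, with a range from 1500 nM to 11000 nM.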

Compound 4, half-maximal inhibitory concentration: 4500 nM
Compound 4: the middle estimate sits 1.1-fold (0.05 log units) below what was measured; low and high end bracket the measured number.
By their numbers in this assay, from the lowest: compounds 3, 4, 1 and 2 (each within the scatter of the next).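

In this assay, benzoyl on the nitrogen on an aromatic ring gives a 1.6-fold higher number from compound 3 to compound 4 (0.19 log units; within the scatter), so this amino to benzamido change, now measured directly, stays within the scatter. Placing (3,4-dichlorophenyl)amino on the carbonyl carbon gives a 1.1-fold lower number from compound 1 to compound 4 (0.05 log units; within the scatter) and a 1.2-fold lower number from compound 2 to compound 4 (0.09 log units; within the scatter), both also within the scatter, so neither the urea nor the amide link can be told apart from the other among these benzamido compounds. Nothing available here speaks to the reason for these small steps.

Going by these compounds, it remains open whether a different group on this nitrogen, such as acetyl or a longer chain like hexanoyl, would produce a step beyond the scatter. On these data alone, it is equally open whether an amine or a carboxylic acid on the benzoyl ring would do so.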